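The compounds below may be only part of what the source reports. "The series", "measured", "known", "first", "only" and "open" are said of these compounds alone.

Measured compounds:
- compound 1 `O=C(O)CCCCCC[C@@H]1[C@@H](CC[C@@H](O)CCc2ccc(C(F)(F)F)cc2)[C@H](O)C[C@@H]1O`: 3630 nM
- compound 2 `COc1ccccc1CC[C@H](O)CC[C@@H]1[C@@H](CCCCCCC(=O)O)[C@@H](O)C[C@H]1O`: 5890 nM

In an in vitro assay on CHO-KI cells for displacement of a labelled ligand from prostaglandin F2-alpha receptor (Homo sapiens) (a higher number here means a weaker inhibitor, a lower number a stronger inhibitor), compound 1 gives 3630 nM and compound 2 gives 5890 nM. Compound 2 stands alongside compound 1 on the numbers shown: the only measured step, a 1.6-fold higher number from compound 1 to compound 2 (0.21 log units; within the scatter), keeps the two within the scatter, so neither compound is separated from the other in this assay.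

Compound 3 `CCc1cccc(CC[C@H](O)CC[C@@H]2[C@@H](CCCCCCC(=O)O)[C@@H](O)C[C@H]2O)c1` is not yet measured. It differs from compound 2 in one place: 3-ethylphenyl in place of 2-methoxyphenyl on a saturated chain carbon, three bonds along the chain from an oxygen on a saturated carbon.

Among the measured compounds shown here, no measured step covers this pair of groups. For the measured compounds named here, the one step available, a 1.6-fold higher number from compound 1 to compound 2 (0.21 log units; within the scatter), exchanges a different aryl group at the same place and stays within the scatter, so it bears on the new step only by showing that an aryl swap at this position has so far moved the number little. On that basis no step beyond the scatter is expected for this assay, in either direction, and the estimate for compound 3 is placed close to compound 2 with a wide range.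

Compound 3 is expected at 4500 nM, with a range from 1500 nM to 14000 nM. The expected step is a 1.3-fold lower number from compound 2 to compound 3 (0.12 log units; within the scatter).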

Compound 3, half-maximal inhibitory concentration: 540 nM
Estimate against measurement, compound 3: 8.3-fold (0.92 log units) above, outside the stated range (below it).
By their numbers in this assay, from the lowest: compound 3; then compounds 1 and 2 (each within the scatter of the next).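

In this assay, among the compounds shown here, the aryl group on a saturated chain carbon, three bonds along the chain from an oxygen on a saturated carbon, can move the number beyond the scatter: 3-ethylphenyl in place of 2-methoxyphenyl gives an 11-fold lower number from compound 2 to compound 3 (1.04 log units; beyond the scatter) and 3-ethylphenyl in place of 4-(trifluoromethyl)phenyl gives a 6.7-fold lower number from compound 1 to compound 3 (0.83 log units; beyond the scatter), so compound 3 separates from both earlier compounds, whereas the only earlier step, a 1.6-fold higher number from compound 1 to compound 2 (0.21 log units; within the scatter), did not separate them. The 2-methoxyphenyl and 3-ethylphenyl groups have the same count of heavy atoms, so the larger step comes without any change in that count, although the oxygen and its hydrogen-bond acceptor are lost. Nothing available explains the change in the number.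

The three aryl groups differ both in the substituent and in its place on the ring, so these compounds do not separate those two changes. On these data alone, it also remains open whether an unsubstituted phenyl, or a propyl or chlorine in place of the ethyl, would hold the number of compound 3 in this assay.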